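Meta fluoro in place of methoxy on a cinnamamide core

The source may report more compounds than this note shows. Statements on the series, on what has been measured and on what is new or still open speak of the compounds shown alone.

Compound 1 `COc1cc(/C=C/C(=O)N2CCC=CS2(=O)=O)cc(OC)c1`: in a functional assay on HeLa cells (Homo sapiens) for inhibition, read by sulforhodamine B assay, with a stated time of 48 h (a lower number here means a stronger inhibitor of growth, a higher number a weaker inhibitor of growth), compound 1 gives < 100 nM, which is a limit of the assay rather than a number.
Compound 2 `COc1cccc(/C=C/C(=O)N2CCC=CS2(=O)=O)c1`: in this assay compound 2 gives 23700 nM.
Compound 3 `O=C(/C=C/c1ccccc1F)N1CCC=CS1(=O)=O`: in this assay compound 3 gives 13700 nM.

Among the numbers shown, compound 2 stands highest; its nearest neighbour is compound 3, and the two lie within the scatter of each other, so no order between them can be claimed. The remaining value, that of compound 1, sits at the limit described by the limit of < 100 nM in this assay, at which 1 of the 3 values shown sits.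

Compound 4 `O=C(/C=C/c1cccc(F)c1)N1CCC=CS1(=O)=O` differs from compound 2 by fluoro in place of methoxy on an aromatic carbon. Among the measured compounds shown here, the only measured step that touches this position is an at least 230-fold higher number from compound 1 to compound 2 (2.37 log units; beyond the scatter), where a methoxy was removed rather than exchanged, so it gives no direct guide to a fluoro at the same place. Compound 3, which carries its fluoro elsewhere on the ring, gives a number within the scatter of compound 2. Nothing shown therefore points to a step beyond the scatter in this assay, in either direction.

Compound 4 is thus expected to give about 15000 nM in this assay, within a range from 5000 nM to 45000 nM. The estimated step of a 1.6-fold lower number from compound 2 to compound 4 (0.20 log units; within the scatter) is expected to stay within the usual scatter.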

Compound 4, concentration for 50% growth inhibition: < 100 nM
Compound 4: only a limit was reported (the forecaster's own chance of this, stated with the estimate: 5%); at least 150-fold (2.17 log units) between middle value and limit.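

In this assay, among the compounds shown here, the place on the ring that holds methoxy in compound 2 proves far more sensitive than the earlier compounds suggested: exchanging methoxy for fluoro there gives an at least 230-fold lower number from compound 2 to compound 4 (2.37 log units; beyond the scatter). Compound 4 gives < 100 nM, which is a limit of the assay and not a number, and it is the same limit that compound 1 reaches: the limit of < 100 nM in this assay, at which 2 of the 4 values shown sit. Compound 3, whose fluoro sits elsewhere on the ring, gives 13700 nM, so these printed values show that where the fluoro stands counts, and that having a fluoro on the ring does not by itself make a compound a strong inhibitor of growth.

As far as these compounds go, how far past the limit compound 4 lies cannot be read, so it remains open whether compound 1 and compound 4 differ at all. Also open, from the compounds shown here alone, is how chloro, hydroxyl, an amine or trifluoromethyl at this same place would behave in this assay, and whether the result for fluoro depends on a second group on the ring.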